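The source may report more compounds than this note shows. Statements on the series, on what has been measured and on what is new or still open speak of the compounds shown alone.

Of the compounds shown here, three sharing one core have been measured in an assay on IMR-32 cells for displacement of a labelled ligand from corticotropin-releasing factor receptor 1 (Homo sapiens), read by scintillation counting, with a stated time of 2 h; on this read-out higher numbers stand for weaker inhibition and lower numbers for stronger inhibition. Compound 1 `CCc1nc(-c2ccc(Cl)cc2Cl)c(CC)nc1NC(COC)COC` gives 224 nM, compound 3 `CCc1nc(NC(CC)CC)c(OC)nc1-c1ccc(Cl)cc1Cl` gives 5.9 nM, and compound 2 `CCc1nc(-c2ccc(Cl)cc2Cl)c(CC)nc1NC(C1CC1)C1CC1` gives 3.7 nM. Compound 2 has the lowest number of the three; compound 3 lies within the scatter of it, while compound 1 stands well apart, that step being a 61-fold lower number from compound 1 to compound 2 (1.78 log units; beyond the scatter). Compound 4 `CCc1nc(N(CC2CC2)CC2CC2)c(CC)nc1-c1ccc(Cl)cc1Cl` differs from compound 2 by bis(cyclopropylmethyl)amino in place of (dicyclopropylmethyl)amino on an aromatic carbon. For the measured compounds named here, the step from compound 1 to compound 2 is the only measured one at this place and shows the group there can move the number greatly; no measured step shows the effect of losing the hydrogen-bond donor. A moderate rise is therefore expected, a 4.1-fold higher number from compound 2 to compound 4 (0.61 log units; beyond the scatter). Compound 4 is estimated at 15 nM, between 3 nM and 80 nM.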

Compound 4, inhibition constant: 26 nM
Compound 4: the middle estimate sits 1.7-fold (0.24 log units) below what was measured; measured number inside the range.
By their numbers in this assay, from the lowest: compounds 2 and 3 (each within the scatter of the next); then compound 4; then compound 1.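

In this assay, bis(cyclopropylmethyl)amino keeps both three-membered rings of (dicyclopropylmethyl)amino but loses the hydrogen-bond donor, giving a 7.0-fold higher number from compound 2 to compound 4 (0.85 log units; beyond the scatter), so this position responds even when the same rings are kept. Even without that donor, the group still gives an 8.6-fold lower number from compound 1 to compound 4 (0.94 log units; beyond the scatter). Nothing measured here explains either shift. As far as these compounds go, the lost donor and the change in the group's size and attachment came together, so their separate contributions remain open. From the compounds shown here alone, how a dipropylamino or morpholine group would read at this position also remains open.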